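A few compounds are considered here, and "the series" means these few. Any claim that something is new, unique, unknown or untested is made for them only; others in the source may bear on it.

In a functional assay on A2780 cells (Homo sapiens) for cytotoxicity, read by MTT assay, with a stated time of 48 h (on this read-out higher numbers stand for weaker inhibition and lower numbers for stronger inhibition), the measured compounds stand as follows.
Compound 1 `CCn1cc(-c2nc3ccccc3[nH]2)c(=O)c2cc(F)c(N3CCNCC3)cc21` gives 800 nM.
Compound 2 `CCn1cc(-c2nc3ccccc3[nH]2)c(=O)c2cc(F)c(N3CCN(C)CC3)cc21` reaches only a limit of the assay, > 5010000 nM.
Compound 3 `CCn1cc(-c2nc3ccccc3s2)c(=O)c2cc(F)c(N3CCN(C)CC3)cc21` gives 114000 nM.

Compound 1 holds the lowest of the two numbers shown; compound 3 sits well above it, beyond the scatter. The step of an at least 6200-fold higher number from compound 1 to compound 2 (3.79 log units; beyond the scatter) is large and ends at the limit of > 5010000 nM in this assay, at which 1 of the 3 values shown sits. The step of an at least 43-fold lower number from compound 2 to compound 3 (1.64 log units; beyond the scatter) is also large, though it starts from that limit and so its true size is not known.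

Compound 4 `CCn1cc(-c2nc3ccc(Cl)cc3[nH]2)c(=O)c2cc(F)c(N3CCNCC3)cc21` differs from compound 1 in one place: chloro in place of hydrogen on an aromatic carbon. Neither measured step touches this position. The step from compound 1 to compound 2 alters the amine nitrogen in a ring, and the step from compound 2 to compound 3 exchanges the whole 1H-benzimidazol-2-yl group for 1,3-benzothiazol-2-yl; neither shows what a chloro on the carbon ring of the 1H-benzimidazol-2-yl does while the rest of compound 1 is kept. Going by the values given here, with no step on this ring to lean on, the expected step in this assay is none beyond the scatter, estimated as a 1.1-fold lower number from compound 1 to compound 4 (0.06 log units; within the scatter). Compound 4 is therefore expected at about 700 nM, in a range from 200 nM to 3000 nM, pending the measurement.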

Compound 4, half-maximal inhibitory concentration: 4900 nM
Estimate against measurement, compound 4: 7.0-fold (0.85 log units) below; measured number above the stated range.
By their numbers in this assay, from the lowest: compound 1; then compound 4; then compound 3. At a limit, above all of these: compound 2.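

In this assay, going by these compounds alone, chloro in place of hydrogen on an aromatic carbon of the six-membered aromatic ring of carbon only gives a 6.1-fold higher number from compound 1 to compound 4 (0.79 log units; beyond the scatter), the first reading at this position, and it shows that the position is not silent to this change while the rest of the molecule is kept. The shift is modest and leaves compound 4 with a measured number, unlike the change on the amine nitrogen in a ring, which gives an at least 6200-fold higher number from compound 1 to compound 2 (3.79 log units; beyond the scatter) and ends at a limit of the assay. Nothing shown gives a cause for the step at the chloro position.

With one substituent at this place, a single reading cannot show whether the upward shift belongs to chloro alone or would also appear with fluoro, methoxy, an amine or a carboxylic acid. Also open, from the compounds shown here alone, is whether chloro has a similar effect on the 1,3-benzothiazol-2-yl group of compound 3, which gives 114000 nM, or with a longer chain than methyl on the ring amine nitrogen.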